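The source may hold more compounds than are shown below. What is called first, only, known or untested is meant among the compounds shown, and "the series" means these compounds.

Working notes on the series. The shared core carries a hydroxamic acid on a benzyl group attached to a nitrogen on an aromatic ring; the substituent on that nitrogen varies. Compound 1 `Cc1ccc(OCCCCN(Cc2ccc(C(=O)NO)cc2)c2ncc(-c3ccc(C)cc3)s2)cc1` gives 1220 nM in a functional assay on PC-3 cells (Homo sapiens) for antiproliferative activity, read by MTT assay, with a stated time of 48 h; a lower number here means a stronger inhibitor of growth, a higher number a weaker inhibitor of growth. Compound 2 `CCCCN(Cc1ccc(C(=O)NO)cc1)c1ncc(-c2ccc(C)cc2)s1` gives 6410 nM in this assay, and compound 3 `CCCCCCN(Cc1ccc(C(=O)NO)cc1)c1ncc(-c2ccc(C)cc2)s1` gives 5270 nM. Among these three numbers compound 3 is second highest: its nearest neighbour is compound 2, which is within the scatter, while compound 1 lies well apart. The steps that trace this are a 5.3-fold higher number from compound 1 to compound 2 (0.72 log units; beyond the scatter) and a 4.3-fold higher number from compound 1 to compound 3 (0.64 log units; beyond the scatter), both modest and beyond the scatter, and a 1.2-fold lower number from compound 2 to compound 3 (0.09 log units; within the scatter), within the scatter.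

Compound 4 `Cc1ccc(-c2cnc(N(Cc3ccc(C(=O)NO)cc3)CC(C)C)s2)cc1` is not yet measured in this assay. It differs from compound 3 by isopropyl in place of pentyl on a saturated chain carbon bound to a nitrogen on an aromatic ring. Among the compounds with values here, the one measured step that alters only the length of a plain saturated chain on this nitrogen is a 1.2-fold lower number from compound 2 to compound 3 (0.09 log units; within the scatter), and it stays within the scatter; the two larger steps both concern loss of the 4-methylphenoxy group, which compound 4 does not carry. The change from compound 3 to compound 4 is therefore expected to give a step of a 1.1-fold higher number from compound 3 to compound 4 (0.06 log units; within the scatter), not beyond the scatter. For compound 4 the estimate in this assay is 6000 nM, with a range from 3000 nM to 12000 nM.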

Compound 4, concentration for 50% growth inhibition: 9340 nM
Estimate against measurement, compound 4: 1.6-fold (0.19 log units) below, within the range that was stated.
By their numbers in this assay, from the lowest: compound 1; then compounds 3, 2 and 4 (each within the scatter of the next).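

In this assay the branched chain of compound 4 does not separate from the plain chains: a 1.8-fold higher number from compound 3 to compound 4 (0.25 log units; within the scatter) and a 1.5-fold higher number from compound 2 to compound 4 (0.16 log units; within the scatter) both stay within the scatter, so isopropyl in place of pentyl or of propyl, on a saturated chain carbon bound to a nitrogen on an aromatic ring, gives no readable change here. Branching thus joins chain length as a change without a resolved effect at this position, and compound 2, compound 3 and compound 4 form a single group, while the chain of compound 1 stands apart, with a 7.7-fold higher number from compound 1 to compound 4 (0.88 log units; beyond the scatter) and so beyond the scatter. Nothing available bears on the reason for these steps.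

From the compounds shown here alone, whether the separation of compound 1 depends on the 4-methylphenoxy group itself remains open, and a plain phenoxy or a methoxy at the end of the chain would bear on that. Also open, going by these compounds, is how an amine or a carboxylic acid at the chain end, or a longer chain carrying the 4-methylphenoxy group, would read in this assay against these four compounds.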